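Amino acid esters on the hydroxymethyl side chain

The source may hold more compounds than are shown below. What is called first, only, known or untested is meant among the compounds shown, and "the series" means these compounds.

Measured so far in a functional assay on HCT-116 cells (Homo sapiens) for inhibition, read by fluorescence, with a stated time of 48 h; on this read-out higher numbers stand for weaker inhibition of growth and lower numbers for stronger inhibition of growth:
compound 1 `CC(C)[C@H](N)C(=O)OCC(C)(C)COC1(c2ccc(Cl)cc2)c2ccccc2C(=O)N1Cc1ccc(Cl)cc1`: 11000 nM
compound 2 `CC(C)(CO)COC1(c2ccc(Cl)cc2)c2ccccc2C(=O)N1Cc1ccc(Cl)cc1`: 50000 nM

Compound 2 gives the higher of the two numbers; its nearest neighbour is compound 1, and the step of a 4.5-fold higher number from compound 1 to compound 2 (0.66 log units; beyond the scatter) records removal of the amino acid ester. Compound 3 `CC(C)(COC(=O)[C@@H](N)c1ccccc1)COC1(c2ccc(Cl)cc2)c2ccccc2C(=O)N1Cc1ccc(Cl)cc1` runs the other way: (amino(phenyl)methyl)carbonyl in place of hydrogen on an oxygen on a saturated carbon. Among the compounds with values here, the only step that bears on it is a 4.5-fold higher number from compound 1 to compound 2 (0.66 log units; beyond the scatter), so a lowering of comparable size in this assay is expected, bringing the number back toward that of compound 1. Compound 3 is therefore estimated at 11000 nM (range 4000 nM to 30000 nM), a step of a 4.5-fold lower number from compound 2 to compound 3 (0.66 log units; beyond the scatter).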

Compound 3, concentration for 50% growth inhibition: 8000 nM
For compound 3 the middle estimate is 1.4-fold (0.14 log units) above the measured one; the measured number falls inside the stated range.
By their numbers in this assay, from the lowest: compounds 3 and 1 (each within the scatter of the next); then compound 2.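

In this assay, a second amino acid ester on the oxygen of the hydroxymethyl side chain again gives stronger inhibition of growth than the free alcohol (a 6.3-fold lower number from compound 2 to compound 3 (0.80 log units; beyond the scatter)). Phenyl in place of isopropyl on the saturated chain carbon bound to the amine nitrogen and the carbonyl carbon does not separate the two esters (a 1.4-fold lower number from compound 1 to compound 3 (0.14 log units; within the scatter)). No available evidence explains the effect of the ester.

From the compounds shown here alone, whether the amine is required remains open; a plain acetyl ester would test this. A glycine ester would show whether either side chain contributes at all.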